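A few compounds are considered here, and "the series" means these few. Any claim that something is new, unique, unknown or untested is made for them only; others in the source may bear on it.

Compounds measured so far:
compound 1 `Cc1n[nH]cc1-c1cccc2c1CCC2c1ncc[nH]1` — 66%
compound 2 `c1cc(-c2nccs2)c2c(c1)C(c1ncc[nH]1)CC2` — 27%

Both were run in a functional assay on CHO cells for agonist activity at Alpha-1D adrenergic receptor (Homo sapiens), read by FLIPR and calcium flux; a lower number here means a smaller maximal response, a higher number a larger maximal response. Within the data shown here, compound 2 stands lowest of the two numbers; the only step on record, a number 39 percentage points lower from compound 1 to compound 2 (beyond the scatter), was large. Compound 3 `c1cc(-c2cn[nH]c2)c2c(c1)C(c1ncc[nH]1)CC2` carries the change (1H-pyrazol-4-yl in place of 1,3-thiazol-2-yl on an aromatic carbon). This reverses the earlier exchange except for the methyl, so the step from compound 1 to compound 2 is the one that bears on it and argues for a rise of comparable size. The expected step is a number 31 percentage points higher from compound 2 to compound 3 (beyond the scatter). For compound 3 the estimate is 58%, with a range from 38% to 76%.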

Compound 3, largest response reached (Emax), in percent of the reference or control that the assay uses: 52%
Beside the measured number, compound 3's estimate is 6 percentage points above it; low and high end bracket the measured number.
By their numbers in this assay, from the lowest: compound 2; then compound 3; then compound 1.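

In this assay 1H-pyrazol-4-yl in place of 1,3-thiazol-2-yl gives a number 25 percentage points higher from compound 2 to compound 3 (beyond the scatter) on this aromatic carbon, so the maximal response at this position follows the ring exchange even without the methyl. Hydrogen in place of methyl gives a number 14 percentage points lower from compound 1 to compound 3 (beyond the scatter) and shows that the methyl counts separately from the ring. Nothing at hand accounts for either step.

The compounds shown carry only five-membered aromatic rings at this position, so the response with a primary amine or a carboxylic acid there stays open. As far as these compounds go, whether the methyl step would carry over to the 1,3-thiazol-2-yl ring also stays open.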